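The source may report more compounds than this note shows. Statements on the series, on what has been measured and on what is new or still open speak of the compounds shown alone.

In a functional assay on A549 cells (Homo sapiens) for inhibition, read by CCK-8 assay, with a stated time of 72 h, tested at 1 uM (on this read-out lower numbers stand for less inhibition of growth and higher numbers for more inhibition of growth at the one concentration tested), compound 2 `CN(C)C(=O)c1cc2cnc(Nc3ccc(NC(=O)C4(C(=O)Nc5ccc(Br)cc5)CC4)cc3)nc2n1C1CCCC1` gives -6.6%, the lowest of the two numbers shown, while compound 1 `CN(C)C(=O)c1cc2cnc(Nc3ccc(NC(=O)C4(C(=O)Nc5ccc(F)cc5)CC4)cc3)nc2n1C1CCCC1` gives 86.6%. Going by the values given here, the only measured step, a number 93.2 percentage points lower from compound 1 to compound 2 (beyond the scatter), is a large one. Compound 3 `COc1cccc(NC(=O)C2(C(=O)Nc3ccc(Nc4ncc5cc(C(=O)N(C)C)n(C6CCCC6)c5n4)cc3)CC2)c1` differs from compound 2 by 3-methoxyphenyl in place of 4-bromophenyl on an amide-type nitrogen. That change touches the same group as the measured step, but brings in a new ring rather than returning to fluoro, so the measured step bears on it only loosely. The step is expected to be a number 46.6 percentage points higher from compound 2 to compound 3 (beyond the scatter), upward and beyond the scatter, because compound 1 gives 86.6%. Compound 3 is estimated at 40%, between -5% and 85%.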

Compound 3, percent growth inhibition at one concentration: 77.2%
Compound 3: middle estimate off by 37.2 percentage points, on the low side; the range from low to high includes it.
By their numbers in this assay, from the lowest: compound 2; then compounds 3 and 1 (each within the scatter of the next).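

In this assay, the change at this amide-type nitrogen gives a number 83.8 percentage points higher from compound 2 to compound 3 (beyond the scatter) and also a number 9.4 percentage points lower from compound 1 to compound 3 (within the scatter) so growth inhibition at this position does not depend on 4-fluorophenyl alone. The low number of compound 2 therefore does not extend to every replacement of that group, since 3-methoxyphenyl stands level with 4-fluorophenyl here. No measured evidence here explains why these aromatic groups differ.

Still open, going by these compounds, is whether the low number belongs to bromo alone. Nor do the compounds shown tell how a chloro group on this ring, a plain phenyl or a pyridine ring would read.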